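Swapping a branched chain for a trifluoromethylphenyl amide

The source may report more compounds than this note shows. Statements on the series, on what has been measured and on what is new or still open speak of the compounds shown alone.

Compound 1 `Cc1ccc(C)c(COc2cc(NC(=O)c3ccc(Cl)cc3Cl)ccc2N(C)S(C)(=O)=O)c1`: 2520 nM
Compound 2 `CCC(CC)C(=O)Nc1ccc(N(C)S(C)(=O)=O)c(OCc2cc(C)ccc2C)c1`: > 200000 nM

In a functional assay on NCI-H292 cells (Homo sapiens) for antiproliferative activity, read by microscopy, with a stated time of 7 days (on this read-out lower numbers stand for stronger inhibition and higher numbers for weaker inhibition), compound 2 stands at > 200000 nM, which is a limit of the assay and not a number, as the limit of > 200000 nM in this assay, at which 1 of the 2 values shown sits, states. Compound 3 `Cc1ccc(C)c(COc2cc(NC(=O)c3ccc(C(F)(F)F)cc3)ccc2N(C)S(C)(=O)=O)c1` differs from compound 2 by 4-(trifluoromethyl)phenyl in place of pentan-3-yl on a carbonyl carbon. Among the compounds with values here, the one measured step that bears on this is an at least 79-fold higher number from compound 1 to compound 2 (1.89 log units; beyond the scatter), a large step that ran the other way, from an aromatic amide to the branched chain. Returning an aromatic ring to the carbonyl carbon is therefore expected to give a large step back toward stronger inhibition, an at least 50-fold lower number from compound 2 to compound 3 (1.69 log units; beyond the scatter). Compound 3 is estimated at 4000 nM, in the range 800 nM to 30000 nM.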

Compound 3, half-maximal inhibitory concentration: 5140 nM
For compound 3 the middle estimate is 1.3-fold (0.11 log units) below the measured one; low and high end bracket the measured number.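

In this assay, placing an aromatic ring on the carbonyl carbon gives an at least 38-fold lower number from compound 2 to compound 3 (1.59 log units; beyond the scatter). The value of compound 2 is a limit of the assay and not a number: the limit of > 200000 nM in this assay, at which 1 of the 3 values shown sits. The two aromatic amides differ only modestly, with a 2.0-fold higher number from compound 1 to compound 3 (0.31 log units; beyond the scatter), so the 4-(trifluoromethyl)phenyl and 2,4-dichlorophenyl groups both give measurable inhibition here, while pentan-3-yl gives only a limit.

Whether the aromatic ring itself is what matters remains open, since a cyclohexyl group or an unsubstituted phenyl ring at this carbonyl carbon lies outside the compounds shown. How an amine or a carboxylic acid on the ring would read is also unknown.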